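Swapping Hydrogen for Bromo on Compound 1

A few compounds are considered here, and "the series" means these few. Any claim that something is new, unique, unknown or untested is made for them only; others in the source may bear on it.

For the measured compounds named here, compound 1 `CC(=O)Nc1ccc(S(=O)(=O)NNc2ccccc2)cc1` gives 71 nM in an assay for inhibition of Indoleamine 2,3-dioxygenase 1 (Homo sapiens), read by spectrophotometry, with stated times of 1 h and 4 h (on this read-out lower numbers stand for stronger inhibition and higher numbers for weaker inhibition), the lowest of the three numbers measured so far. Its nearest neighbour is compound 3 `CC(=O)Nc1ccc(S(=O)(=O)NNc2ccc(Cl)cc2)cc1`, which gives 155 nM in this assay; the furthest is compound 2 `CC(=O)Nc1ccc(S(=O)(=O)NNc2ccc(C(F)(F)F)cc2)cc1`, which gives 1610 nM in this assay. Compound 4 `CC(=O)Nc1ccc(S(=O)(=O)NNc2ccc(Br)cc2)cc1` has not yet been measured. It differs from compound 1 in a single place: bromo in place of hydrogen on an aromatic carbon.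

Going by the values given here, two measured steps bear on this change, since each also replaces the same hydrogen of compound 1 with another group. The step to the chloro compound, a 2.2-fold higher number from compound 1 to compound 3 (0.34 log units; beyond the scatter), was modest. The step to the trifluoromethyl compound, a 23-fold higher number from compound 1 to compound 2 (1.36 log units; beyond the scatter), was large, and the direct comparison a 10-fold lower number from compound 2 to compound 3 (1.02 log units; beyond the scatter) shows how far those two groups lie apart. Bromo, like chloro, enters as one heavy atom, so the expectation leans toward the modest end, though a somewhat larger weakening than with chloro seems plausible. Compound 4 is therefore expected to show a step of a 3.5-fold higher number from compound 1 to compound 4 (0.55 log units; beyond the scatter), a weakening beyond the scatter. The estimate for compound 4 in this assay is 250 nM, with a range from 100 nM to 700 nM.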

Compound 4, half-maximal inhibitory concentration: 130 nM
Beside the measured number, compound 4's estimate is 1.9-fold (0.28 log units) above it; low and high end bracket the measured number.
By their numbers in this assay, from the lowest: compounds 1, 4 and 3 (each within the scatter of the next, the first and the last beyond it); then compound 2.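

In this assay, for the compounds shown here, bromo is the first group at this place on the aromatic ring whose step away from hydrogen stays inside the usual scatter: a 1.8-fold higher number from compound 1 to compound 4 (0.26 log units; within the scatter), whereas the chloro step from compound 1 to compound 3 lay just beyond it. Bromo and chloro themselves cannot be told apart here, since a 1.2-fold lower number from compound 3 to compound 4 (0.08 log units; within the scatter) is also within the scatter, so compound 3 and compound 4 read as one level rather than as a trend running from one halogen to the next. The large gap belongs to trifluoromethyl alone among these compounds, as a 12-fold lower number from compound 2 to compound 4 (1.09 log units; beyond the scatter) now joins the earlier chloro comparison, showing that replacing this hydrogen does not in itself bring a large rise in the number.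

No measurement given here explains why trifluoromethyl stands so far from the two halogens. From the compounds shown here alone, it also remains open whether fluoro, methoxy, an amine or a carboxylic acid in the same place would stay close to compound 1 and compound 4 or would move toward compound 2.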